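Thiosemicarbazone series: chloro to methyl on the aryl amine

A few compounds are considered here, and "the series" means these few. Any claim that something is new, unique, unknown or untested is made for them only; others in the source may bear on it.

Going by the values given here, the three measured members all carry a thiosemicarbazone arm. Compound 1 `S=C(N/N=C/c1ccc2ccccc2n1)Nc1cccc(Cl)c1` is the weakest of them in a functional assay on HeLa cells (Homo sapiens) for antiproliferative activity, read by sulforhodamine B assay, with a stated time of 72 h (on this read-out higher numbers stand for weaker inhibition and lower numbers for stronger inhibition), where compound 1 gives 52500 nM. Compound 2 `Cc1csc2sc(/C=N/NC(N)=S)c(C)c12` gives 1120 nM in this assay, and compound 3 `CN(C)C(=S)N/N=C/c1ccc2cccnc2n1` gives 970 nM; both numbers lie well below that of compound 1, by gaps beyond the scatter. Compound 2 and compound 3 sit within the scatter of each other, so no order is drawn between them.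

Compound 4 `Cc1cccc(NC(=S)N/N=C/c2ccc3ccccc3n2)c1` is not yet measured. It differs from compound 1 by methyl in place of chloro on an aromatic carbon. Among the compounds with values here, no measured pair shows this change, so nothing here tells how the read-out answers it; donors, acceptors and charge stay as they were. The expected step is small, with no firm direction, and most likely within the scatter. Compound 4 is therefore expected to give about 45000 nM, with a range from 15000 nM to 150000 nM. The step this estimate means is a 1.2-fold lower number from compound 1 to compound 4 (0.07 log units; within the scatter), expected to stay within the scatter.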

Compound 4, half-maximal inhibitory concentration: > 100000 nM
Compound 4 was reported as a limit; the forecaster's own chance of this, stated with the estimate: 15%; middle value at least 2.2-fold (0.34 log units) away from the limit.
By their numbers in this assay, from the lowest: compounds 3 and 2 (each within the scatter of the next); then compound 1. At a limit, above all of these: compound 4.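

Compound 4 stands only as a limit in this assay, at > 100000 nM. Methyl in place of chloro on this aromatic carbon gives an at least 1.9-fold higher number from compound 1 to compound 4 (0.27 log units; that floor lies within the scatter), so this swap brings no sign of stronger inhibition, although the floor of the step alone does not separate the two compounds. The true size of the step stays unfixed, and the read-out gives no upper end for it here: the limit of > 100000 nM in this assay, at which 1 of the 4 values shown sits.

Going by these compounds, what an amine, a methoxy group or a carboxylic acid on the same aromatic carbon would do to the read-out stays open. Also open, on these data alone, is whether 3-chlorophenyl and 3-methylphenyl differ at all on the core of compound 1, or whether this position matters less than the rest of the structure.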